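The source may hold more compounds than are shown below. What is called first, only, known or untested is meant among the compounds shown, and "the series" means these compounds.

Measured so far:
compound 1, `Nc1scc(CN2CCN(c3ccc(Cl)cc3Cl)CC2)c1C(=O)c1ccc(Cl)cc1`: -74%
compound 2, `Nc1scc(CN2CCN(c3cccnc3)CC2)c1C(=O)c1ccc(Cl)cc1`: -23%

Both numbers come from a functional assay on CHO cells with adenosine receptor A1 (Homo sapiens) as the target, read by cAMP accumulation and immunoassay, with a stated time of 6 min, tested at 10 uM; a lower number here means a stronger effect, a higher number a weaker effect of the compound at the concentration tested. Compound 2 stands highest of the two, separated from compound 1 by a number 51 percentage points higher from compound 1 to compound 2 (beyond the scatter). Compound 3, `Nc1scc(CN2CCN(c3ccncc3)CC2)c1C(=O)c1ccc(Cl)cc1`, differs from compound 2 by pyridin-4-yl in place of pyridin-3-yl on an amine nitrogen in a ring. Within the data shown here, the one measured step, a number 51 percentage points higher from compound 1 to compound 2 (beyond the scatter), exchanges a dichlorophenyl for a pyridyl and says nothing about exchanging one pyridyl for the other; no measured pair shows that change. The expected step is therefore none beyond the scatter, a number 2 percentage points lower from compound 2 to compound 3 (within the scatter). Compound 3 is estimated at -25%, with a range from -50% to 0%.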

Compound 3, a percentage reported as activity, at one concentration (the size of the read-out at that concentration, not a potency): -15%
Beside the measured number, compound 3's estimate is 10 percentage points below it; the range from low to high includes it.
By their numbers in this assay, from the lowest: compound 1; then compounds 2 and 3 (each within the scatter of the next).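

In this assay, pyridin-4-yl in place of pyridin-3-yl on the amine nitrogen in a ring gives a number 8 percentage points higher from compound 2 to compound 3 (within the scatter), so the two pyridyl groups shown are not separated at this position. Pyridin-4-yl in place of 2,4-dichlorophenyl gives a number 59 percentage points higher from compound 1 to compound 3 (beyond the scatter), so the large gap from the dichlorophenyl compound appears with both pyridyl groups. Nothing available bears on the reason for either step.

Open, on these data alone, is how pyridin-2-yl or unsubstituted phenyl would read at this nitrogen. Also open, as far as these compounds go, is whether a single chlorine on the phenyl ring would keep the value of compound 1.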